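Swapping the benzyl substituent on a triazole-linked flavanone

The source may hold more compounds than are shown below. What is called first, only, known or untested is meant among the compounds shown, and "the series" means these compounds.

Compound 1 `COc1ccc([C@@H]2CC(=O)c3c(O)cc(OCc4cn(Cc5ccc(F)cc5)nn4)cc3O2)cc1O`: 15100 nM
Compound 2 `COc1ccc([C@@H]2C/C(=N\O)c3c(O)cc(OCc4cn(Cc5ccccc5Cl)nn4)cc3O2)cc1O`: 13400 nM

Of the compounds shown here, two have been measured in a functional assay on RAW264.7 cells (Mus musculus) for inhibition, read by Griess assay, with stated times of 2 h and 24 h; a higher number here means a weaker inhibitor, a lower number a stronger inhibitor. Compound 1 gives 15100 nM in this assay, and compound 2 gives 13400 nM. Compound 1 stands level with compound 2: the gap between the two values lies within the scatter of repeated measurements, so no order can be read from them. Among the measured compounds shown here, compound 2 also differs from compound 1 in more than one place, so no single step can be drawn between them.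

Compound 3 `COc1ccc([C@@H]2CC(=O)c3c(O)cc(OCc4cn(Cc5ccccc5C(F)(F)F)nn4)cc3O2)cc1O` has not yet been measured. It differs from compound 1 in one place: 2-(trifluoromethyl)phenyl in place of 4-fluorophenyl on a saturated chain carbon bound to an aromatic nitrogen. For the measured compounds named here, no measured pair shows this change, so its effect is unknown. Both measured values sit close together, and the expectation for compound 3 is a step of a 1.3-fold lower number from compound 1 to compound 3 (0.10 log units; within the scatter), no larger than the scatter. Compound 3 is therefore estimated at 12000 nM, within a range from 5000 nM to 30000 nM.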

Compound 3, half-maximal inhibitory concentration: 12500 nM
The estimate for compound 3 lay 1.0-fold (0.02 log units) below the measured number; low and high end bracket the measured number.
By their numbers in this assay, from the lowest: compounds 3, 2 and 1 (each within the scatter of the next).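

In this assay, among the compounds shown here, the first single-place comparison at this position gives a 1.2-fold lower number from compound 1 to compound 3 (0.08 log units; within the scatter), for 2-(trifluoromethyl)phenyl in place of 4-fluorophenyl on a saturated chain carbon bound to an aromatic nitrogen. The entering group has more heavy atoms and a different fluorine content, yet this exchange leaves compound 1 and compound 3 level, so this one change does not separate them in this assay. Nothing available accounts for this outcome.

On these data alone, it remains open whether any benzyl substituent at this place can move the number beyond the scatter, for example an amine or a carboxylic acid on the ring, or a longer chain in place of the benzyl carbon. The compounds shown also leave the separate contribution of the oxime in compound 2 unresolved, as that compound differs from compound 1 in more than one place.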